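The source may hold more compounds than are shown below. What is called first, only, known or untested is meant among the compounds shown, and "the series" means these compounds.

In an assay on NIH3T3 cells with Urotensin-2 receptor (Homo sapiens) as the target (a lower number here means a smaller maximal response, a higher number a larger maximal response), compound 1 `Cc1ccccc1C(=O)OC(CCN(C)C)c1ccc(Cl)cc1` gives 126%.
In this assay compound 2 `CN(C)CCC(OC(=O)c1cn(C)c2ccccc12)c1ccc(Cl)cc1` gives 104%.
In this assay compound 3 `COc1ccc(C(=O)OC(CCN(C)C)c2ccc(Cl)cc2)cc1` gives 84%.

Compound 3 has the lowest of the three numbers, and both compound 1 and compound 2 stand beyond the scatter above it. Compound 4 `Cc1ccsc1C(=O)OC(CCN(C)C)c1ccc(Cl)cc1` differs from compound 3 in one place: 3-methylthiophen-2-yl in place of 4-methoxyphenyl on a carbonyl carbon. Among the compounds with values here, the one measured step that bears on this position is a number 42 percentage points lower from compound 1 to compound 3 (beyond the scatter), where the 4-methoxyphenyl entered and the number fell sharply. Its departure is therefore expected to raise the number, though the 3-methylthiophen-2-yl is not the group of compound 1, so a smaller rise is estimated. Compound 4 is expected to give 105%, within 82% to 128%. This estimate means a step of a number 21 percentage points higher from compound 3 to compound 4 (beyond the scatter).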

Compound 4, largest response reached (reported as efficacy), in percent of the reference or control that the assay uses: 119%
For compound 4 the middle estimate is 14 percentage points below the measured one, and the stated range covers the measured number.
By their numbers in this assay, from the lowest: compound 3; then compound 2; then compounds 4 and 1 (each within the scatter of the next).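

On this carbonyl carbon, the 3-methylthiophen-2-yl gives a number 35 percentage points higher from compound 3 to compound 4 (beyond the scatter) in this assay, so the low number of compound 3 is not shared by every replacement at this place. The change from the 2-methylphenyl amounts to a number 7 percentage points lower from compound 1 to compound 4 (within the scatter), which shows that a six-membered aromatic ring of carbon only is not needed here for a large maximal response. No available evidence explains either step.

From the compounds shown here alone, how an unsubstituted thiophen-2-yl or a 4-methylphenyl would compare on the same carbonyl carbon remains open. Whether the methyl group matters in compound 4 therefore also remains unsettled.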